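A few compounds are considered here, and "the series" means these few. Any claim that something is new, unique, unknown or untested is made for them only; others in the source may bear on it.

Working notes on a small set of glycoside-type compounds sharing one core, followed in a functional assay on HeLa cells (Homo sapiens) for cytotoxicity, read by MTT assay, with a stated time of 48 h; on this read-out lower numbers stand for an effect already at smaller amounts and higher numbers for an effect only at larger amounts of compound.

Two members have numbers. Compound 1 `CO[C@H]1O[C@H](COc2ccc(OC3CCCCC3)cc2)[C@@H](O)[C@H](O)[C@H]1Oc1ccc(OC2CCCCC2)cc1` gives 14000 nM in this assay. Compound 2 `CO[C@H]1O[C@H](COc2ccccc2C(C)C)[C@@H](O)[C@H](O)[C@H]1Oc1ccc(OC2CCCCC2)cc1` gives 47000 nM in this assay. Of these two numbers, compound 2 holds the highest; its nearest neighbour is compound 1, whose number is lower by a margin that lies beyond the usual scatter of repeated measurements. Within the data shown here, no single-point step between the two measured compounds is available, so the gap between compound 1 and compound 2 is noted only as what the two values show.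

The next compound, compound 3 `CO[C@H]1O[C@H](COc2ccc(C3CCCCC3)cc2)[C@@H](O)[C@H](O)[C@H]1Oc1ccc(OC2CCCCC2)cc1`, has not yet been measured in this assay. It differs from compound 2 in one place: 4-cyclohexylphenyl in place of 2-isopropylphenyl on an oxygen on a saturated carbon. Compound 3 is expected to move back toward the number of compound 1, whose value 14000 nM sets the lower of the two known points, so the step from compound 2 to compound 3 is estimated as a moderate drop, a 2.1-fold lower number from compound 2 to compound 3 (0.33 log units; beyond the scatter). For compound 3 the estimated value in this assay is 22000 nM, with a plausible range from 9000 nM to 55000 nM.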

Compound 3, half-maximal effective concentration: 10000 nM
Compound 3: the middle estimate sits 2.2-fold (0.34 log units) above what was measured; the measured number falls inside the stated range.
By their numbers in this assay, from the lowest: compounds 3 and 1 (each within the scatter of the next); then compound 2.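

In this assay the place on an oxygen on a saturated carbon now has a comparison in one place: 4-cyclohexylphenyl in place of 2-isopropylphenyl gives a 4.7-fold lower number from compound 2 to compound 3 (0.67 log units; beyond the scatter) and this step lies beyond the scatter, which the gap between the two earlier compounds, differing in more than one respect, could not show as the effect of a single change. The second step, a 1.4-fold lower number from compound 1 to compound 3 (0.15 log units; within the scatter) in the same read-out, lies within the scatter, so cyclohexyl in place of cyclohexyloxy on an aromatic carbon gives no readable difference, and this terminal group tolerates that exchange in these two compounds. Nothing measured here bears on why the values stand as they do.

The step from 2-isopropylphenyl to 4-cyclohexylphenyl changes the alkyl group and its place on the aromatic ring together, so the compounds shown cannot separate these two contributions. Also open, on these data alone, is whether an amine or a carboxylic acid in place of the cyclohexyl would keep the number of compound 3 or move it beyond the scatter.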